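A Trifluoromethylphenyl Swap and Its Expected Cytotoxicity

This account rests on a few compounds, and the source may have more. Where it says the series, first, only, none or still open, it means among the compounds named here.

Compound 1 `COc1ccc(-n2cc(-c3ccccc3)c(-c3ccc4c(c3)NC(=O)CO4)n2)cc1`: 95.6%
Compound 2 `O=C1COc2ccc(-c3[nH]c(-c4c[nH]c5ncccc45)nc3-c3ccccc3)cc2N1`: 100%

In a functional assay on A549 cells (Homo sapiens) for cytotoxicity, read by colorimetric assay and MTT assay, with a stated time of 3 days, tested at 1 uM (a lower number here means a stronger effect, a higher number a weaker effect of the compound at the concentration tested), compound 1 gives 95.6%, and compound 2 gives 100%. On these two numbers compound 2 sits alongside compound 1, the gap between them within the usual scatter, so neither shows a marked effect at the concentration tested. Compound 3 `O=C1COc2ccc(-c3[nH]c(-c4ccc(C(F)(F)F)cc4)nc3-c3ccccc3)cc2N1` is not yet measured. It differs from compound 2 by a group of 10 heavy atoms (7 carbon, 3 fluorine; one six-membered aromatic ring of carbon only) in place of a group of 9 heavy atoms (7 carbon, 2 nitrogen; one five-membered aromatic ring with 1 hetero atom, one six-membered aromatic ring with 1 hetero atom), on an aromatic carbon. Within the data shown here, with no measured step to lean on, the step of a number 5 percentage points lower from compound 2 to compound 3 (within the scatter) is expected to be small, none beyond the scatter. Compound 3 is therefore estimated at 95%, within 80% to 105%.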

Compound 3, a percentage reported as activity, at one concentration (the size of the read-out at that concentration, not a potency): 103%
Beside the measured number, compound 3's estimate is 8 percentage points below it, within the range that was stated.
By their numbers in this assay, from the lowest: compounds 1, 2 and 3 (each within the scatter of the next).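

On the aromatic carbon between two ring nitrogen atoms, 4-(trifluoromethyl)phenyl replaces a group with a five-membered and a six-membered aromatic ring, and this assay shows a number 3 percentage points higher from compound 2 to compound 3 (within the scatter). So this position accepts a carbon-only aromatic ring with no hydrogen-bond donor or acceptor without a change that stands out from the scatter at the concentration tested. No measurement at hand explains this result. Going by these compounds, whether an amine or a carboxylic acid at this position would give a clearly lower number remains open. The same holds for a longer chain.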